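A few compounds are considered here, and "the series" means these few. Any claim that something is new, unique, unknown or untested is made for them only; others in the source may bear on it.

Measured compounds:
Compound 1 `c1coc(-c2ccccc2NCC2=NCCN2)c1`, in a functional assay for activation of Alpha-1A adrenergic receptor (Homo sapiens), read by calcium flux (on this read-out higher numbers stand for an effect only at larger amounts of compound and lower numbers for an effect already at smaller amounts), compound 1 gives 0.468 nM.
Compound 2 `Cc1nc(-c2ccccc2NCC2=NCCN2)cs1`, in this assay compound 2 gives 4.47 nM.
Compound 3 `Cc1ccsc1-c1ccccc1NCC1=NCCN1`, in this assay compound 3 gives 0.851 nM.

Compound 2 stands at the highest number of the three: the step of a 5.3-fold lower number from compound 2 to compound 3 (0.72 log units; beyond the scatter) and the step from compound 2 back to compound 1, the reverse of a 9.6-fold higher number from compound 1 to compound 2 (0.98 log units; beyond the scatter), are both beyond the scatter, so compound 2 is the weakest of the set, while compound 1 and compound 3 lie within the scatter of each other, a 1.8-fold higher number from compound 1 to compound 3 (0.26 log units; within the scatter).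

Compound 4 `CO/N=C(\C)c1ccccc1NCC1=NCCN1` carries the change (a group of 5 heavy atoms (3 carbon, 1 nitrogen, 1 oxygen; no ring) in place of a group of 6 heavy atoms (4 carbon, 1 nitrogen, 1 sulfur; one five-membered aromatic ring with 2 hetero atoms), on an aromatic carbon). Among the compounds with values here, none of the measured steps replaces a ring by a group without a ring, so no step bears on it directly; the two steps at compound 2 only show that exchanging the group on that aromatic carbon moves the number by a modest amount. With a group of a new kind, a step of that order in either direction is plausible, and the estimate leans toward a number near or slightly above that of compound 2. The expected step is a 1.3-fold higher number from compound 2 to compound 4 (0.13 log units; within the scatter). For compound 4 the estimated value in this assay is 6 nM, within the range 1.5 nM to 25 nM.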

Compound 4, half-maximal effective concentration: 20.9 nM
Compound 4: the middle estimate sits 3.5-fold (0.54 log units) below what was measured, and the stated range covers the measured number.
By their numbers in this assay, from the lowest: compounds 1 and 3 (each within the scatter of the next); then compound 2; then compound 4.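

In this assay, within the data shown here, the first group without a ring at this aromatic carbon gives the highest number so far, above every ring-bearing compound: a 4.7-fold higher number from compound 2 to compound 4 (0.67 log units; beyond the scatter), a 25-fold higher number from compound 3 to compound 4 (1.39 log units; beyond the scatter) and a 45-fold higher number from compound 1 to compound 4 (1.65 log units; beyond the scatter). The earlier compounds had shown only exchanges among five-membered aromatic rings, two of which ended within the scatter of each other, whereas this change sets all three ring-bearing compounds clearly apart from compound 4, even though compound 2 and compound 4 have the same counts of hydrogen-bond donors and acceptors. No measurement is at hand that explains this shift.

With compound 4 as the only group without a ring, the compounds shown leave open whether the higher number goes with the absence of a ring in general or with this particular group. Also open, on these data alone, is how other groups on this aromatic carbon would compare, such as a phenyl ring, a plain acetyl group, an amine or a carboxylic acid.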